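The source may hold more compounds than are shown below. What is called first, only, known or untested is meant among the compounds shown, and "the series" means these compounds.

Measured compounds:
- compound 1, `COc1cc(-c2ccnc3cc(-c4ccc(C)c(C)c4)nn23)cc(OC)c1OC`: 391 nM
- compound 2, `COc1cc(-c2ccnc3cc(-c4cn(C(=O)OC(C)(C)C)c5ccccc45)nn23)cc(OC)c1OC`: 3070 nM

Of the compounds shown here, two from this study have been measured in a functional assay on B16-F0 cells (Mus musculus) for inhibition, read by CCK-8 assay, with a stated time of 48 h; on this read-out lower numbers stand for stronger inhibition and higher numbers for weaker inhibition. Compound 1 gives 391 nM, the lower of the two numbers, while compound 2 gives 3070 nM, a number beyond the usual scatter away from that of compound 1. For the measured compounds named here, the two compounds share a core and differ in the aryl group attached to it, but as they differ in more than one place, no single step between them can be read off.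

Compound 3, `COc1cc(-c2ccnc3cc(-c4ccc5cnn(C)c5c4)nn23)cc(OC)c1OC`, has not yet been measured in this assay. It is derived from compound 1 by one change: 1-methyl-1H-indazol-6-yl in place of 3,4-dimethylphenyl on an aromatic carbon. Going by the values given here, nothing measured so far isolates the effect of swapping one aryl group for another on the core, so the expectation for compound 3 rests on compound 1 alone and on the general size of the change. A step of modest size, in the direction of weaker inhibition, is expected from compound 1 to compound 3, a 1.8-fold higher number from compound 1 to compound 3 (0.25 log units; within the scatter), roughly at the edge of the scatter. Compound 3 is therefore estimated at 700 nM, with a plausible range from 250 nM to 2000 nM.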

Compound 3, half-maximal inhibitory concentration: 1000 nM
Estimate against measurement, compound 3: 1.4-fold (0.15 log units) below; the measured number falls inside the stated range.
By their numbers in this assay, from the lowest: compound 1; then compound 3; then compound 2.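

In this assay, for the compounds shown here, putting 1-methyl-1H-indazol-6-yl in place of 3,4-dimethylphenyl gives a 2.6-fold higher number from compound 1 to compound 3 (0.41 log units; beyond the scatter), the only single change that can be read at this aromatic carbon of the five-membered aromatic ring with 2 nitrogen. The step shows that the number at this carbon responds to the aryl group, and that a group with a second aromatic ring, 2 nitrogen and 2 hydrogen-bond acceptors still leaves compound 3 at 1000 nM, although the change costs some inhibition relative to compound 1. No measurement on these compounds accounts for the size or direction of this step.

As far as these compounds go, with a single step, the separate contributions of the fused five-membered ring, its nitrogen atoms and its methyl group cannot be told apart, so it stays open how an unsubstituted phenyl or a 1H-indazol-6-yl group without the methyl would compare with 3,4-dimethylphenyl. From the compounds shown here alone, it also stays open how a phenyl group carrying an amine or a carboxylic acid at this carbon would fare, and what changes elsewhere on the shared core would do.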